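Branching the Ketone Chain of a Glutamate Receptor Modulator

The compounds below may be only part of what the source reports. "The series", "measured", "known", "first", "only" and "open" are said of these compounds alone.

For the measured compounds named here, compound 2 `CCC(=O)c1ccc(OCCCCOc2ccc(F)c(C(=O)O)c2)c(C)c1O` gives 18.4% in an assay on HEK293 cells for positive allosteric modulation of metabotropic glutamate receptor 3 (Rattus norvegicus), read by thallium flux, with a stated time of 2.5 min (on this read-out lower numbers stand for smaller maximal responses and higher numbers for larger maximal responses), the lower of the two numbers so far, with compound 1 `CCCC(=O)c1ccc(OCCCCOc2ccc(F)c(C(=O)O)c2)c(C)c1O` as its nearest neighbour at 56.9%. Going by the values given here, the one step that bears on the next change is a number 38.5 percentage points lower from compound 1 to compound 2 (beyond the scatter). Compound 3 `Cc1c(OCCCCOc2ccc(F)c(C(=O)O)c2)ccc(C(=O)C(C)C)c1O` differs from compound 2 by methyl in place of hydrogen on a saturated chain carbon bound to a carbonyl carbon and a saturated chain carbon. Since adding a methyl back at a nearby chain position is the reverse kind of change, an increase beyond the scatter is expected, though smaller than the step already seen between compound 1 and compound 2. The estimated step is a number 21.6 percentage points higher from compound 2 to compound 3 (beyond the scatter). Compound 3 is therefore expected to reach 40%, with a range from 20% to 62%.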

Compound 3, largest response reached (reported as percent of maximum), in percent of the reference or control that the assay uses: 31.3%
Beside the measured number, compound 3's estimate is 8.7 percentage points above it; measured number inside the range.
By their numbers in this assay, from the lowest: compound 2; then compound 3; then compound 1.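

Branching the chain recovers only part of the response in this assay, with methyl in place of hydrogen on the saturated chain carbon bound to the carbonyl carbon giving a number 12.9 percentage points higher from compound 2 to compound 3 (beyond the scatter). Isopropyl in place of propyl on a carbonyl carbon gives a number 25.6 percentage points lower from compound 1 to compound 3 (beyond the scatter), so the response depends on where the added methyl sits and not only on its presence. No measurement here explains this difference. From the compounds shown here alone, whether a longer chain or a cyclopropyl group on the carbonyl carbon would exceed compound 1 remains open.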